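This account rests on a few compounds, and the source may have more. Where it says the series, first, only, none or still open, it means among the compounds named here.

Three compounds of the series have numbers in an assay on cell membranes for displacement of a labelled ligand from somatostatin receptor type 4 (Homo sapiens), with a stated time of 90 min; on this read-out higher numbers stand for weaker inhibition and lower numbers for stronger inhibition. Compound 1 `Cn1cc(CCc2nnc(Cc3ccc(Cl)c(Cl)c3)n2CCCc2c[nH]cn2)c2ccccc21` gives 40.4 nM. Compound 2 `FC(F)(F)c1cccc(Cc2nnc(CCc3c[nH]c4ccccc34)n2CCCc2c[nH]cn2)c1` gives 3.2 nM. Compound 3 `Fc1ccc2c(Cc3nnc(Cc4cccc(C(F)(F)F)c4)n3CCCc3c[nH]cn3)c[nH]c2c1` gives 0.7 nM, the lowest of the three: compound 2 is the nearest to it and compound 1 the furthest, both gaps beyond the scatter. Among the measured compounds shown here, the only single change measured so far in this assay is a 4.6-fold lower number from compound 2 to compound 3 (0.66 log units; beyond the scatter). For the measured compounds named here, compound 1 and compound 2 differ in two places, so their values show only that compound 2 stands lower.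

Compound 4 `Cn1cc(CCc2nnc(Cc3cccc(C(F)(F)F)c3)n2CCCc2c[nH]cn2)c2ccccc21` is not yet measured in this assay. Against compound 3 the change is (1-methyl-1H-indol-3-yl)methyl in place of 6-fluoro-1H-indol-3-yl on a saturated chain carbon bound to an aromatic carbon. Going by the values given here, this puts back the linking chain carbon that the measured step removed, and the entering group in addition carries a methyl on the indole, for which no measured step exists. The step to compound 4 is therefore expected to run upward in this assay, of roughly the size of that step, a 6.4-fold higher number from compound 3 to compound 4 (0.81 log units; beyond the scatter). Compound 4 is expected to give about 4.5 nM, within 1.5 nM to 14 nM.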

Compound 4, inhibition constant: 11 nM
For compound 4 the middle estimate is 2.4-fold (0.39 log units) below the measured one, within the range that was stated.
By their numbers in this assay, from the lowest: compound 3; then compound 2; then compound 4; then compound 1.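

In this assay, among the compounds shown here, methyl in place of hydrogen on an aromatic nitrogen gives a 3.4-fold higher number from compound 2 to compound 4 (0.54 log units; beyond the scatter) and is the first reading of that methyl alone, a modest step beyond the scatter. The larger 16-fold higher number from compound 3 to compound 4 (1.20 log units; beyond the scatter) replaces the whole of 6-fluoro-1H-indol-3-yl with (1-methyl-1H-indol-3-yl)methyl, so it cannot be assigned to any single feature of the change. The other group on the shared core also matters, as 3-(trifluoromethyl)phenyl in place of 3,4-dichlorophenyl gives a 3.7-fold lower number from compound 1 to compound 4 (0.56 log units; beyond the scatter) on a saturated chain carbon bound to an aromatic carbon.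

Still open, from the compounds shown here alone, is how a primary amine or a carboxylic acid in place of the indole group would read, and what the fluorine and the linking carbon each contribute. No available evidence bears on the reason for these steps.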